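This account rests on a few compounds, and the source may have more. Where it says the series, first, only, none or still open, it means among the compounds named here.

In an ADME assay on HeLa Rh cells (Homo sapiens) for cytotoxicity, read by microscopy (on this read-out higher numbers stand for lower toxicity in this test and lower numbers for higher toxicity in this test), three compounds that share one core have been measured, each differing only in a single aromatic group. Compound 1, `COc1cc(CC(O)c2ccc(-c3ccc(C=O)cc3)cc2)c([N+](=O)[O-])cc1OC`, gives only a limit of the assay, > 245000 nM. Compound 2, `COc1cc(CC(O)c2ccc(-c3ccc(C(F)(F)F)cc3)cc2)c([N+](=O)[O-])cc1OC`, gives 4100 nM. Compound 3, `COc1cc(CC(O)c2ccc(-c3cccs3)cc2)c([N+](=O)[O-])cc1OC`, gives 11000 nM, the highest of the two plain numbers; its nearest neighbour is compound 2, and the step of a 2.7-fold higher number from compound 2 to compound 3 (0.43 log units; beyond the scatter) is modest but beyond the scatter. The step of an at least 22-fold lower number from compound 1 to compound 3 (1.34 log units; beyond the scatter) is large. On these data alone, it starts from the limit of > 245000 nM in this assay, at which 1 of the 3 values shown sits, of compound 1, so its true size stays open.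

Compound 4, `COc1cc(CC(O)c2ccc(-c3ccoc3)cc2)c([N+](=O)[O-])cc1OC`, is the next compound and differs from compound 3 in one place: furan-3-yl in place of thiophen-2-yl on an aromatic carbon. Both measured steps that end at compound 3 replace a 4-formylphenyl or a 4-(trifluoromethyl)phenyl with thiophen-2-yl; neither swaps one five-membered heteroaromatic ring for another, so they bear only loosely on this change. Given that the smaller of them was modest, a step of similar or smaller size, in no firm direction, is expected here. The estimate is that compound 4 gives about 15000 nM in this assay, within a range from 5000 nM to 50000 nM, which means an expected step of a 1.4-fold higher number from compound 3 to compound 4 (0.13 log units; within the scatter).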

Compound 4, half-maximal cytotoxic concentration: 5300 nM
For compound 4 the middle estimate is 2.8-fold (0.45 log units) above the measured one; measured number inside the range.
By their numbers in this assay, from the lowest: compounds 2 and 4 (each within the scatter of the next); then compound 3. At a limit, above all of these: compound 1.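

Even a swap between two five-membered aromatic rings, each with one hetero atom and the same count of heavy atoms, moves the read-out at this place, para to a large group, in this assay: the result is a 2.1-fold lower number from compound 3 to compound 4 (0.32 log units; beyond the scatter), so the earlier steps, which all involved a six-membered aromatic ring, did not show that this position responds to so close a change. The step of a 1.3-fold higher number from compound 2 to compound 4 (0.11 log units; within the scatter) puts furan-3-yl level with 4-(trifluoromethyl)phenyl, so having a five-membered ring here does not by itself set compound 4 apart from compound 2, and compound 3 goes against any grouping by ring size. On these data alone, the step of an at least 46-fold lower number from compound 1 to compound 4 (1.66 log units; beyond the scatter) shows compound 4 again far from compound 1, whose value is a limit, so the true size of that step stays open: the limit of > 245000 nM in this assay, at which 1 of the 4 values shown sits.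

This change alters both the hetero atom and the point of attachment, and the compounds shown do not separate the two, which a furan-2-yl or a thiophen-3-yl group could do. As far as these compounds go, how an amine or a carboxylic acid at this place would read also remains open.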